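Swapping the ring on the piperazine nitrogen: compound 4

This account rests on a few compounds, and the source may have more. Where it says the series, first, only, none or still open, it means among the compounds named here.

Compound 1 `Nc1ccccc1NC(=O)c1ccc(CSC(=S)N2CCN(c3ccncc3)CC2)cc1` gives 90.7% in a functional assay on A-375 cells (Homo sapiens) for antiproliferative activity, read by CCK-8 assay, with a stated time of 72 h, tested at 8 uM; on this read-out lower numbers stand for a weaker effect and higher numbers for a stronger effect at the one concentration tested.
Compound 2 `Nc1ccccc1NC(=O)c1ccc(CSC(=S)N2CCN(Cc3ccccc3)CC2)cc1` gives 29.3% in this assay.
Compound 3 `Nc1ccccc1NC(=O)c1ccc(CSC(=S)N2CCN(c3ccccc3F)CC2)cc1` gives 79.5% in this assay.

Compound 3 stands second highest of the three: compound 1 lies above it, as seen in a number 11.2 percentage points lower from compound 1 to compound 3 (beyond the scatter), and compound 2 lies far below it, as seen in a number 50.2 percentage points higher from compound 2 to compound 3 (beyond the scatter). The new compound 4 `Nc1ccccc1NC(=O)c1ccc(CSC(=S)N2CCN(c3ncccn3)CC2)cc1` changes compound 3 in one place: pyrimidin-2-yl in place of 2-fluorophenyl on an amine nitrogen in a ring. Among the measured compounds shown here, two measured steps bear on this. The step from a six-membered aromatic ring of carbon only to a six-membered aromatic ring with nitrogen, seen in a number 11.2 percentage points lower from compound 1 to compound 3 (beyond the scatter), was modest, while replacing the benzyl group with a ring set directly on the nitrogen, seen in a number 50.2 percentage points higher from compound 2 to compound 3 (beyond the scatter), was large. Compound 4 keeps a ring set directly on that nitrogen and adds nitrogen atoms to it, so a small upward step, a number 5.5 percentage points higher from compound 3 to compound 4 (within the scatter), is expected, toward compound 1 rather than compound 2. Compound 4 is therefore estimated at 85%, with a likely range from 65% to 96%.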

Compound 4, a percentage reported as inhibition, at one concentration (the size of the read-out at that concentration, not a potency): 67.9%
For compound 4 the middle estimate is 17.1 percentage points above the measured one, and the stated range covers the measured number.
By their numbers in this assay, from the lowest: compound 2; then compound 4; then compound 3; then compound 1.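

In this assay, the presence of nitrogen in the ring does not by itself set the result on this amine nitrogen. Pyrimidin-2-yl lies below the carbon-only 2-fluorophenyl, a number 11.6 percentage points lower from compound 3 to compound 4 (beyond the scatter), and also below pyridin-4-yl, a number 22.8 percentage points lower from compound 1 to compound 4 (beyond the scatter), so compound 4 goes against the idea, suggested by compound 1 alone, that a nitrogen-containing ring outdoes a carbon-only ring. All the same, compound 4 keeps a wide lead over the benzyl compound, a number 38.6 percentage points higher from compound 2 to compound 4 (beyond the scatter), and no measurement here explains any of these differences.

As far as these compounds go, it remains open whether pyridin-2-yl or pyridin-3-yl would match pyridin-4-yl, and whether a small non-ring group such as methyl or acetyl on this nitrogen would behave like benzyl. Readings at a single concentration also leave open how these compounds rank in potency.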